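The source may hold more compounds than are shown below. What is called first, only, known or untested is meant among the compounds shown, and "the series" means these compounds.

Working notes on the series. Compound 1 `O=C(Nc1ccccc1)C1CCN(C/C=C/c2ccccc2)CC1` in a functional assay on A549 cells (Homo sapiens) for inhibition, read by MTT assay, with a stated time of 72 h (on this read-out higher numbers stand for weaker inhibition and lower numbers for stronger inhibition), gives 69700 nM. Compound 2 `O=C(Nc1cccc(F)c1)C1CCN(C/C=C/c2ccccc2)CC1` in this assay gives 43300 nM, and compound 3 `O=C(Nc1cccc(Br)c1)C1CCN(C/C=C/c2ccccc2)CC1` in this assay gives 16500 nM. The steps: a 1.6-fold lower number from compound 1 to compound 2 (0.21 log units; within the scatter); a 4.2-fold lower number from compound 1 to compound 3 (0.63 log units; beyond the scatter); a 2.6-fold lower number from compound 2 to compound 3 (0.42 log units; beyond the scatter). Compound 3 carries the lowest number of the three, and both of its steps to the others lie beyond the scatter.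

Compound 4 `O=C(Nc1ccc(F)c(Br)c1)C1CCN(C/C=C/c2ccccc2)CC1` is not yet measured. It differs from compound 3 by fluoro in place of hydrogen on an aromatic carbon. The same kind of change has been made once already, from compound 1 to compound 2, as fluoro in place of hydrogen on an aromatic carbon, and there it produced a 1.6-fold lower number from compound 1 to compound 2 (0.21 log units; within the scatter). The two cores differ by bromo in place of hydrogen on an aromatic carbon. The surroundings are not the same: in compound 2 the entering fluoro sits meta to a large group, while in compound 4 it sits ortho to a bromo group and para to a large group, so this is the same kind of change, not the same change.

Within the data shown here, from compound 3 to compound 4 a step of about a 1.5-fold lower number from compound 3 to compound 4 (0.18 log units; within the scatter) is expected in this assay, resting on the single earlier step from compound 1 to compound 2, a 1.6-fold lower number from compound 1 to compound 2 (0.21 log units; within the scatter), which was within the scatter. Compound 4 is therefore estimated at 11000 nM, with a range from 5000 nM to 25000 nM.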

Compound 4, half-maximal inhibitory concentration: 11700 nM
Compound 4: the middle estimate sits 1.1-fold (0.03 log units) below what was measured; measured number inside the range.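

On the two cores, fluoro in place of hydrogen gives the same kind of result in this assay, with a 1.4-fold lower number from compound 3 to compound 4 (0.15 log units; within the scatter) set against the earlier step, and the two do not differ: the same change on two cores in this assay, a 1.6-fold lower number (0.21 log units; within the scatter) from compound 1 to compound 2 and a 1.4-fold lower number (0.15 log units; within the scatter) from compound 3 to compound 4, 1.1-fold (0.06 log units) apart, within the scatter of two such steps. This shows that the change carried over between the core of compound 1 and the core of compound 3 without a step beyond the scatter on either, even though in compound 4 the fluoro sits ortho to a bromo group and para to a large group; it does not show that fluoro itself moves the number, and two pairs give no rule for other cores. The wider steps, a 3.7-fold lower number from compound 2 to compound 4 (0.57 log units; beyond the scatter) and a 6.0-fold lower number from compound 1 to compound 4 (0.78 log units; beyond the scatter), lie beyond the scatter, but each replaces the whole aromatic group on the amide-type nitrogen and cannot be read as a fluoro effect.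

The compounds shown leave open whether the same fluoro step would hold with chloro or trifluoromethyl in place of the bromo group. They also leave open how an amine or a carboxylic acid on that aromatic ring would read in this assay.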